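The compounds below may be only part of what the source reports. "The series", "measured", "known", "first", "only" and "open" are said of these compounds alone.

Measured so far in a functional assay on B16-F10 cells (Mus musculus) for inhibition, read by MTT assay, with a stated time of 72 h; a lower number here means a stronger inhibitor, a higher number a weaker inhibitor:
compound 1 `N#Cc1c(Nc2ccc(Cl)cc2)nc(SCc2cn(Cc3ccccc3Cl)nn2)nc1-c1ccccc1` 1590 nM
compound 2 `COc1ccccc1Nc1nc(SCc2cn(Cc3ccccc3Cl)nn2)nc(-c2ccccc2)c1C#N` 7860 nM
compound 3 `N#Cc1c(Nc2ccccc2F)nc(SCc2cn(Cc3ccccc3Cl)nn2)nc1-c1ccccc1` 5230 nM

Compound 3 stands second highest of the three: the step of a 1.5-fold lower number from compound 2 to compound 3 (0.18 log units; within the scatter) lies within the scatter, while a 3.3-fold higher number from compound 1 to compound 3 (0.52 log units; beyond the scatter) lies beyond it. Compound 4 `N#Cc1c(Nc2ccccc2)nc(SCc2cn(Cc3ccccc3Cl)nn2)nc1-c1ccccc1` differs from compound 3 by hydrogen in place of fluoro on an aromatic carbon. Among the measured compounds shown here, the steps of a 4.9-fold higher number from compound 1 to compound 2 (0.69 log units; beyond the scatter) and a 3.3-fold higher number from compound 1 to compound 3 (0.52 log units; beyond the scatter) exchange the whole aryl and are modest; the nearest precedent, a 1.5-fold lower number from compound 2 to compound 3 (0.18 log units; within the scatter), exchanges one ortho substituent for another and stays within the scatter. For the measured compounds named here, no measured step removes the substituent entirely. The step of a 1.2-fold lower number from compound 3 to compound 4 (0.07 log units; within the scatter) is therefore expected to stay within the scatter. For compound 4 the estimate in this assay is 4500 nM, range 1500 nM to 14000 nM.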

Compound 4, half-maximal inhibitory concentration: 28300 nM
The estimate for compound 4 lay 6.3-fold (0.80 log units) below the measured number; the whole stated range lies below it.
By their numbers in this assay, from the lowest: compound 1; then compounds 3 and 2 (each within the scatter of the next); then compound 4.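

In this assay compound 4, with the plain anilino, is the weakest of the four: hydrogen in place of fluoro (a 5.4-fold higher number from compound 3 to compound 4 (0.73 log units; beyond the scatter)), of methoxy (a 3.6-fold higher number from compound 2 to compound 4 (0.56 log units; beyond the scatter)) and of chloro (an 18-fold higher number from compound 1 to compound 4 (1.25 log units; beyond the scatter)) all raise the number. Any of the three substituents therefore goes with a lower number than hydrogen, which exchanges among substituted aryls could not show. No measurement at hand accounts for this.

Still open, on these data alone, is whether substituent or place matters more, which 2-chlorophenyl and 4-fluorophenyl would separate. As far as these compounds go, an amine or a carboxylic acid on this aryl also remains untested ground.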